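The compounds below may be only part of what the source reports. "The series", "measured", "known", "first", "only" and "open" are said of these compounds alone.

Measured so far:

- compound 1, `Cc1ccc(N2C(=O)CS/C2=N/N=C/c2c[nH]c3ccccc23)cc1`: > 100000 nM
- compound 2, `S=C(N/N=C/c1c[nH]c2ccc(Br)cc12)Nc1cccc2ccccc12`: 6150 nM

Two compounds have been tested in an ADME assay on HaCaT cells (Homo sapiens) for inhibition, read by spectrophotometry and sulforhodamine B assay, with a stated time of 48 h (a higher number here means a weaker inhibitor of growth, a lower number a stronger inhibitor of growth), and they stand very differently on the numbers shown. Compound 1 gives > 100000 nM, which is a limit of the assay and not a number. That leaves compound 2 with the only actual number shown in this assay , namely 6150 nM. Among the compounds with values here, the single limit, (the limit of > 100000 nM in this assay, at which 1 of the 2 values shown sits), therefore marks the one point of comparison available for compound 2.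

The next compound, compound 3, `S=C(N/N=C/c1c[nH]c2ccccc12)Nc1cccc2ccccc12`, is made from compound 2 by one change: hydrogen in place of bromo on an aromatic carbon. Within the data shown here, no pair of measured compounds differs in just one place, so no measured step exists from which the effect of this change could be read. With that in mind, the expectation for this change in this assay is a small step, if any, toward weaker growth inhibition, most likely not beyond the usual scatter. The step from compound 2 to compound 3 is accordingly expected to be a 1.5-fold higher number from compound 2 to compound 3 (0.17 log units; within the scatter). Compound 3 is estimated to give about 9000 nM in this assay , within a range of 3000 nM to 30000 nM.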

Compound 3, concentration for 50% growth inhibition: 590 nM
Beside the measured number, compound 3's estimate is 15-fold (1.18 log units) above it, outside the stated range (below it).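

In this assay, within the data shown here, this pair gives the first measured reading for this position, and the step runs the opposite way to a small weakening: a 10-fold lower number from compound 2 to compound 3 (1.02 log units; beyond the scatter). This step is large and beyond the usual scatter, so on this aromatic carbon, which is part of a fused or bridged system of two rings, compound 3, with hydrogen, is clearly the stronger inhibitor of growth of the two, and the bromo is not needed for the growth inhibition seen in compound 2. Nothing measured here accounts for the size or direction of the change.

This single pair cannot show whether the loss of inhibition with bromo is particular to that atom or would also appear with another group on the same carbon, such as fluorine, chlorine, methoxy or an amine. It also leaves open whether bromo would have the same effect on any other carbon of that ring.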